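This account rests on a few compounds, and the source may have more. Where it says the series, first, only, none or still open, it means among the compounds named here.

Measured so far:
- compound 1, `Cc1ccc(-c2nc3ncccc3o2)cc1`: 5%
- compound 2, `Fc1ccc(-c2nc3cccnc3o2)cc1`: 27%
- compound 3, `COc1ccc(Br)c(-c2nc3ncccc3o2)c1`: 8%

In a functional assay on the whole organism for inhibition, with Rattus norvegicus as the target, at a dose of 30 mg/kg (on this read-out lower numbers stand for less inhibition and higher numbers for more inhibition at the one dose given (going by the name of the read-out)), compound 1 gives 5%, the lowest of the three numbers. Compound 3 stands nearest to compound 1, within the scatter of it, so the two are not told apart. Among the compounds with values here, compound 2 stands furthest, beyond the scatter above compound 1; compound 2 carries a fluoro group where compound 1 carries methyl, but it also differs in the shared core, and no step between the two is given, so its value shows only that a fluoro-bearing relative of this series can reach a higher number in this assay.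

Compound 4, `Fc1ccc(-c2nc3ncccc3o2)cc1`, is not yet measured. It differs from compound 1 by fluoro in place of methyl on an aromatic carbon.

Within the data shown here, no step for such a change is known from measured pairs. Given that compound 1 gives 5% and compound 3 gives 8%, the expected step from compound 1 to compound 4 is small, towards a higher number, and most likely within the scatter, estimated at a number 7 percentage points higher from compound 1 to compound 4 (within the scatter). Compound 4 is estimated at 12% in this assay, with a range from 2% to 30%.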

Compound 4, a percentage reported as inhibition, in the whole organism at one dose (the size of the read-out at that dose, not a potency): 28%
Compound 4: middle estimate off by 16 percentage points, on the low side, and the stated range covers the measured number.
By their numbers in this assay, from the lowest: compounds 1 and 3 (each within the scatter of the next); then compounds 2 and 4 (each within the scatter of the next).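

In this assay, fluoro in place of methyl on an aromatic carbon, para to a group of 9 heavy atoms, gives a number 23 percentage points higher from compound 1 to compound 4 (beyond the scatter), so with the core of compound 1 held fixed, this one position moves the read-out beyond the scatter. The higher number of compound 2 could not be tied to the fluoro group alone, as that compound also differs in the shared core; now compound 4 at 28% and compound 2 at 27% lie within the scatter of each other, so that core difference does not tell the two fluoro compounds apart in this assay. No measurement at hand accounts for the step, which stands only as an observed difference at one dose.

The compounds shown do not tell whether the step comes from gaining fluoro or from losing methyl, and a plain hydrogen, a chloro group or an amine at this position would help separate the two readings. With a single dose, they also leave open how the compounds would compare across other doses.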